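The source may report more compounds than this note shows. Statements on the series, on what has been measured and on what is new or still open speak of the compounds shown alone.

Working notes on the chlorophenyl series. Among the measured compounds shown here, in a physicochemical assay for lipophilicity, measured as octanol-water partition, at pH 7.4 (a higher number here means a more lipophilic compound, a lower number a more polar compound), compound 1 (`O=C(N[C@H]1CN(S(=O)(=O)c2ccccc2)C[C@@H]1C(=O)N[C@H]1CCCNC1)c1cc(-c2ccc(Cl)cc2)on1`) gives 2.1 and compound 2 (`O=C(N[C@H]1CN(S(=O)(=O)c2ccccc2)C[C@@H]1C(=O)N[C@H]1CCCNC1)c1cc(-c2ccccc2Cl)on1`) gives 1.9, so compound 2 stands within the scatter of the only other number available. Next comes compound 3 (`O=C(N[C@H]1CN(S(=O)(=O)c2ccccc2)C[C@@H]1C(=O)N[C@H]1CCCNC1)c1cc(-c2ccc(Cl)cc2Cl)on1`), which differs from compound 2 by chloro in place of hydrogen on an aromatic carbon, in words chloro in place of hydrogen on an aromatic carbon, or 2-chlorophenyl to 2,4-dichlorophenyl. For the measured compounds named here, only one measured step bears on this, a number 0.20 log units lower from compound 1 to compound 2 (within the scatter), and it moves a chloro group rather than adding one. It gives no size for an added chloro, and the series holds no measured addition. Going by the values given here, with the structural change as the only guide, a rise beyond the scatter is expected in this assay. The expected change is a number 0.60 log units higher from compound 2 to compound 3 (beyond the scatter). For compound 3 the estimated value is 2.5, expected to fall between 2.2 and 2.9.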

Compound 3, distribution coefficient: 2.5
Estimate against measurement, compound 3: no gap at the digits printed; the range from low to high includes it.
By their numbers in this assay, from the lowest: compounds 2 and 1 (each within the scatter of the next); then compound 3.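

In this assay a chloro group added on the 2-chlorophenyl ring, para to a large group and meta to a chloro group, gives a number 0.60 log units higher from compound 2 to compound 3 (beyond the scatter) and so has its first measured size. Added to the other monochloro compound, to give the same 2,4-dichlorophenyl ring, a chloro group gives a number 0.40 log units higher from compound 1 to compound 3 (beyond the scatter) and again clears the scatter, which moving a chloro group from compound 1 to compound 2 did not do. Nothing measured here accounts for the size of either step.

Open is whether the step is particular to chloro: the compounds shown hold no methyl group, methoxy group or amine in place of the same hydrogen. Also open, as far as these compounds go, is whether the same addition gives a step of this size on a ring that carries no other chloro group.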